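A few compounds are considered here, and "the series" means these few. Any claim that something is new, unique, unknown or untested is made for them only; others in the source may bear on it.

Measured compounds:
Compound 1, `O=S(=O)(Nc1cc(CO)ccc1O)c1ccc(-c2ccc(Br)cc2)cc1` — in a functional assay on J774 cells (Mus musculus) for cytotoxicity, read by resazurin assay, with a stated time of 72 h (a higher number here means a weaker inhibitor, a lower number a stronger inhibitor), compound 1 gives 1000 nM.
Compound 2, `O=S(=O)(Nc1cccc(CO)c1)c1ccc(-c2ccc3cc[nH]c3c2)cc1` — in this assay compound 2 gives 2500 nM.

Among the compounds with values here, of the two numbers so far, compound 2 carries the higher one; its nearest neighbour is compound 1, whose number is lower by a margin that lies beyond the usual scatter, so compound 2 is the weaker of the two measured compounds in this assay.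

Compound 3, `O=S(=O)(Nc1cccc(CO)c1)c1ccc(-c2ccc(Br)cc2)cc1`, has not been measured. It departs from compound 2 in a single spot: 4-bromophenyl in place of 1H-indol-6-yl on an aromatic carbon. Within the data shown here, no pair of measured compounds differs in exactly this way, so the size of the step has to be guessed. Among the measured compounds shown here, the only guide is that compound 1, which also ends in a 4-bromophenyl group, gives 1000 nM in this assay; since the rest of compound 1 is not the same as that of compound 3, this guide is weak. On that basis compound 3 is expected to give a somewhat lower number than compound 2, with a step of a 1.7-fold lower number from compound 2 to compound 3 (0.22 log units; within the scatter) that may well stay close to the scatter. The estimate for compound 3 in this assay is 1500 nM, within a range from 600 nM to 4000 nM.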

Compound 3, half-maximal inhibitory concentration: 2500 nM
Estimate against measurement, compound 3: 1.7-fold (0.22 log units) below, and the stated range covers the measured number.
By their numbers in this assay, from the lowest: compound 1; then compounds 2 and 3 (each within the scatter of the next).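

Compounds 1 and 2 differed in more than one place, so neither change could be read alone; compound 3 separates them. In this assay, replacing 1H-indol-6-yl with 4-bromophenyl on this aromatic carbon gives no change at the digits printed from compound 2 to compound 3 (within the scatter), so at this position the two-ring group and the single-ring group cannot be told apart, at least with the shared core of compound 3, whereas hydrogen in place of hydroxy on an aromatic carbon gives a 2.5-fold higher number from compound 1 to compound 3 (0.40 log units; beyond the scatter), a modest step beyond the scatter that places the only readable difference among these compounds at the hydroxy group. Nothing in hand accounts for either step.

The compounds shown leave open whether the flat result at the 4-bromophenyl position would hold for a phenyl ring carrying a carboxylic acid or an amine, as only two groups have been compared there. They also leave open whether the hydroxy step would recur with 1H-indol-6-yl in place of 4-bromophenyl, and whether a methoxy group or an amine could stand in for the hydroxy group.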